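Sulfonate ureas: chloropropyl to cyclopentylmethyl step

A few compounds are considered here, and "the series" means these few. Any claim that something is new, unique, unknown or untested is made for them only; others in the source may bear on it.

Among the measured compounds shown here, compound 2 `O=C(NCCCCl)Nc1ccc(S(=O)(=O)Oc2ccccc2I)cc1` gives 7600 nM in a functional assay on MCF7 cells (Homo sapiens) for antiproliferative activity, read by sulforhodamine B assay, with a stated time of 48 h (a higher number here means a weaker inhibitor, a lower number a stronger inhibitor), the highest of the two numbers so far; compound 1 `CCCNC(=O)Nc1ccc(S(=O)(=O)Oc2ccccc2I)cc1` gives 2900 nM. For the measured compounds named here, the only measured step, a 2.6-fold higher number from compound 1 to compound 2 (0.42 log units; beyond the scatter), bears only loosely on the present change, (cyclopentyl in place of 2-chloroethyl on a saturated chain carbon bound to an amide-type nitrogen), which gives compound 3 `O=C(NCC1CCCC1)Nc1ccc(S(=O)(=O)Oc2ccccc2I)cc1`. Going by the values given here, no measured step exchanges a chlorine-bearing chain for a carbocycle, so the expected size rests on compound 2 standing above compound 1 by a 2.6-fold higher number from compound 1 to compound 2 (0.42 log units; beyond the scatter) and on the change removing the chlorine. A modest fall in number is expected, roughly a 2.4-fold lower number from compound 2 to compound 3 (0.38 log units; beyond the scatter). Compound 3 is estimated at 3200 nM, within 1100 nM to 9500 nM.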

Compound 3, half-maximal inhibitory concentration: 6600 nM
Estimate against measurement, compound 3: 2.1-fold (0.31 log units) below; the range from low to high includes it.
By their numbers in this assay, from the lowest: compound 1; then compounds 3 and 2 (each within the scatter of the next).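

In this assay, cyclopentylmethyl in place of 3-chloropropyl leaves the number within the scatter (a 1.2-fold lower number from compound 2 to compound 3 (0.06 log units; within the scatter)), so losing the chlorine does not by itself return the series to the level of compound 1. Cyclopentyl in place of ethyl at this place gives a 2.3-fold higher number from compound 1 to compound 3 (0.36 log units; beyond the scatter), so compound 1 remains the lowest of the three. No evidence available here accounts for either step. Going by these compounds, whether an amine, a hydroxyl or a longer unbranched chain at this place would fall below compound 1 remains open.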